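Chloro in place of fluoro: from compound 3 to compound 4

A few compounds are considered here, and "the series" means these few. Any claim that something is new, unique, unknown or untested is made for them only; others in the source may bear on it.

Measured so far in a functional assay on P388 cells (Mus musculus) for inhibition (a lower number here means a stronger inhibitor, a higher number a weaker inhibitor), as half-maximal inhibitory concentration
compound 1 `Cc1ccc(/C=C2\CCc3ccccc3C2=O)cc1` gives 17700 nM as a number
compound 2 `O=C1CCCCC/C1=C\c1ccccc1` gives > 50000 nM as a limit
compound 3 `O=C1CCCCC/C1=C\c1ccc(F)cc1` gives > 50000 nM as a limit

Compound 3 has no number in this assay and stands only at its limit of > 50000 nM on the scale. For the measured compounds named here, compound 2 sits at the same limit, as recorded in the limit of > 50000 nM in this assay, at which 2 of the 3 values shown sit, and the only measured step is a step that the two limits leave unreadable from compound 2 to compound 3 so it gives no size to carry forward. Going by the values given here, only compound 1 gives a number, 17700 nM but its core differs from that of compound 3 and no step links the two.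

The next change leads to compound 4 `O=C1CCCCC/C1=C\c1ccc(Cl)cc1` and is chloro in place of fluoro on an aromatic carbon in words, chloro in place of fluoro on an aromatic carbon. With no readable step to draw on, no step beyond the scatter is expected in this assay and no direction can be assigned. The expected change is an at least 1.1-fold lower number from compound 3 to compound 4 (0.04 log units; that floor lies within the scatter) and this is an estimate only. A further limit reading is the likeliest outcome. For compound 4 the estimated value is 45000 nM with an expected range from 18000 nM to 90000 nM in this assay.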

Compound 4, half-maximal inhibitory concentration: 19100 nM
Compound 4: middle estimate off by 2.4-fold (0.37 log units), on the high side; measured number inside the range.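

In this assay, for the compounds shown here, chloro in place of fluoro on an aromatic carbon of a six-membered aromatic ring of carbon only, para to a group of 9 heavy atoms, is the first change on the shared core to yield a number, and the step lies beyond the scatter (an at least 2.6-fold lower number from compound 3 to compound 4 (0.41 log units; beyond the scatter)). Chloro in place of hydrogen at the same place reads the same way (an at least 2.6-fold lower number from compound 2 to compound 4 (0.41 log units; beyond the scatter)), so what sits at this position can move the number in this assay. Both steps are floors and not sizes, and the step between compound 2 and compound 3 cannot be read, because those two compounds stand only at a limit: the limit of > 50000 nM in this assay, at which 2 of the 4 values shown sit.

Going by these compounds, whether the lower number continues past chloro or belongs to chloro alone stays open, and bromo, methoxy or an amine at this place would test that. Also open, on these data alone, are the true size of the chloro step and whether chloro has the same effect on the core of compound 1, which gives 17700 nM and differs from compound 4 in more than one place.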